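The compounds below may be only part of what the source reports. "The series", "measured", "known", "first", "only" and "open" are said of these compounds alone.

Compound 1, `COc1ccc(C[S+]([O-])c2ncccc2C(=O)Nc2ccncc2)c(OCCO)c1`. In an ADME assay (on this read-out lower numbers stand for a shorter-lived compound and higher numbers for a longer-lived compound), compound 1 gives < 0.02 h, which is a limit of the assay rather than a number.
Compound 2, `COCOCCOc1cc(OC)ccc1C[S+]([O-])c1ncccc1C(=O)Nc1ccncc1`. In this assay compound 2 gives < 0.02 h, again only a limit.
Compound 3, `COc1ccc(C[S+]([O-])c2ncccc2C(=O)Nc2ccncc2)c(OCCF)c1`. In this assay compound 3 gives < 0.02 h, also a limit.

The three compounds share one core and differ only in a single substituent. Because all three values sit at the limit of < 0.02 h in this assay, at which 3 of the 3 values shown sit, none of the steps between them can be sized: a step that the two limits leave unreadable from compound 1 to compound 2, a step that the two limits leave unreadable from compound 1 to compound 3 and a step that the two limits leave unreadable from compound 2 to compound 3 are each unreadable. Compound 3 therefore stands at the limit, alongside compound 1 and compound 2, and no order among the three can be stated.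

Compound 4, `CCOc1cc(OC)ccc1C[S+]([O-])c1ncccc1C(=O)Nc1ccncc1`, differs from compound 3 by hydrogen in place of fluoro on a saturated chain carbon, two bonds along the chain from an oxygen on an aromatic ring. Going by the values given here, the steps that bear on this change are the three just named, each of them unreadable; together they show only that three different versions of this substituent all left the half-life at the limit. Among the compounds with values here, the author therefore expects no step in this assay that could be sized, and most likely a further limit. The expected step is a number no lower from compound 3 to compound 4 (the limit leaves the size open). Compound 4 is estimated at 0.02 h, within a range from 0.005 h to 0.08 h.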

Compound 4, half-life: < 0.02 h
Compound 4 was reported as a limit; the forecaster's own chance of this, stated with the estimate: 70%; the middle value lies on the limit itself.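

In this assay compound 4 gives < 0.02 h, which is a limit and not a number, so none of the steps linking compound 1, compound 2 and compound 3 to compound 4 can be read: the limit of < 0.02 h in this assay, at which 4 of the 4 values shown sit.

The compounds shown leave open the actual half-life of each of the four compounds, and whether swapping these chain substituents changes it at all.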